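Sulfonyl aryl variation on a shared quinoline-free core series

The source may report more compounds than this note shows. Statements on the series, on what has been measured and on what is new or still open speak of the compounds shown alone.

Two compounds of this series have numbers in an assay on isolated protein for displacement of a labelled ligand from metabotropic glutamate receptor 5 (Homo sapiens), with a stated time of 60 min, tested at 1 uM; a lower number here means less inhibition, a higher number more inhibition at the concentration tested (going by the name of the read-out). Compound 1 `Cc1ccc(S(=O)(=O)c2cnc3ccc(F)cc3c2N2CCC(C)CC2)cc1C` gives 92%. Compound 2 `CC1CCN(c2c(S(=O)(=O)c3ccc(C#N)cc3)cnc3ccc(F)cc23)CC1` gives 75%, which is the lowest of the two numbers; its nearest neighbour is compound 1, whose number is higher by a step that lies beyond the scatter. Among the compounds with values here, the one measured step, a number 17 percentage points lower from compound 1 to compound 2 (beyond the scatter), accompanies the exchange of 3,4-dimethylphenyl for 4-cyanophenyl on the sulfonyl sulfur.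

Compound 3 `Cc1ccc(S(=O)(=O)c2cnc3ccc(F)cc3c2N2CCC(C)CC2)cc1F` is not yet measured. It differs from compound 2 in one place: 3-fluoro-4-methylphenyl in place of 4-cyanophenyl on a sulfonyl sulfur. The entering 3-fluoro-4-methylphenyl shares a methyl-bearing ring with the 3,4-dimethylphenyl of compound 1, while the 4-cyanophenyl that leaves is the group present in compound 2. The step from compound 1 to compound 2 therefore bears on this change in reverse: removing the nitrile cost a modest amount, and putting a methyl-bearing ring back is expected to recover most of it.

For compound 3 a step of a number 13 percentage points higher from compound 2 to compound 3 (beyond the scatter) is expected, upward. Compound 3 is estimated at 88%, with a range from 74% to 97%.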

Compound 3, a percentage reported as inhibition, at one concentration (the size of the read-out at that concentration, not a potency): 86%
For compound 3 the middle estimate is 2 percentage points above the measured one, within the range that was stated.
By their numbers in this assay, from the lowest: compound 2; then compounds 3 and 1 (each within the scatter of the next).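

In this assay the result is a number 11 percentage points higher from compound 2 to compound 3 (beyond the scatter), so among the compounds shown, the higher level at the sulfonyl sulfur is not confined to the 3,4-dimethylphenyl group: a second methyl-bearing ring, 3-fluoro-4-methylphenyl, also stands above 4-cyanophenyl. Fluoro in place of methyl on an aromatic carbon of that ring gives a number 6 percentage points lower from compound 1 to compound 3 (within the scatter), so this exchange leaves the two compounds indistinguishable in this assay and adds a fluorine-bearing group to the ones that keep the number high. Nothing measured here gives a reason for either step.

The compounds shown cannot separate the loss of the nitrile from the gain of the methyl-bearing ring, a question that an unsubstituted phenyl or a 4-methoxyphenyl on the sulfonyl sulfur would bear on directly. On these data alone, the amine on the shared core is the same in all three compounds, so it remains open whether these steps would hold with a morpholine or a dimethylamine in its place.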